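A few compounds are considered here, and "the series" means these few. Any claim that something is new, unique, unknown or untested is made for them only; others in the source may bear on it.

In a functional assay on PC-3 cells (Homo sapiens) for cytotoxicity, read by MTT assay, with a stated time of 72 h (a lower number here means a stronger inhibitor, a higher number a weaker inhibitor), compound 1 `O=C(Nc1ccc(Oc2ccnc3[nH]ccc23)cc1)c1cc(-c2ccc(Cl)cc2)ccn1` gives 25100 nM. Compound 2 `O=C(Nc1ccc(Oc2ccnc3[nH]ccc23)c(F)c1)c1cc(-c2ccccc2)ccn1` gives only a limit of the assay, > 10000 nM, so no number is known for it. Compound 3 `Cc1ccc(-c2ccnc(C(=O)Nc3ccc(Oc4ccnc5[nH]ccc45)c(F)c3)c2)c(C)c1` gives 4010 nM, the lowest of the two numbers in this assay, with compound 1 the nearest and higher.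

For the measured compounds named here, the one single-point change measured so far, an at least 2.4-fold lower number from compound 2 to compound 3 (0.39 log units; beyond the scatter), came with a 2,4-dimethylphenyl in place of a phenyl and lowered the number, though the size of that step is only bounded by the limit of compound 2 (the limit of > 10000 nM in this assay, at which 1 of the 3 values shown sits).

Compound 4 `O=C(Nc1ccc(Oc2ccnc3[nH]ccc23)c(F)c1)c1cc(-c2ccc(F)cc2F)ccn1` is compound 3 with 2,4-difluorophenyl in place of 2,4-dimethylphenyl on an aromatic carbon. The substitution pattern on that outer ring stays the same, while methyl groups give way to fluorine atoms. Going by the values given here, no measured step mirrors that swap, and the one related step only shows that adding groups to the outer ring can help. A small change in either direction, perhaps a slightly higher number, is therefore expected, giving a 1.5-fold higher number from compound 3 to compound 4 (0.18 log units; within the scatter). Compound 4 is estimated at 6000 nM, between 2000 nM and 20000 nM.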

Compound 4, half-maximal inhibitory concentration: > 10000 nM
Compound 4 was reported as a limit (the forecaster's own chance of this, stated with the estimate: 25%); middle value at least 1.6-fold (0.22 log units) from the limit.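

On the aromatic carbon opposite the ring nitrogen, 2,4-difluorophenyl in place of 2,4-dimethylphenyl gives an at least 2.4-fold higher number from compound 3 to compound 4 (0.39 log units; beyond the scatter) in this assay. For the compounds shown here, the earlier step showed only that the outer ring with two methyl groups did better than the bare phenyl; this one shows that keeping the same substitution pattern is not enough, since the gain is lost, at least in part, when fluorine atoms take the place of the methyl groups. The step between compound 2 and compound 4 cannot be read, because each of the two compounds gives only a limit: the limit of > 10000 nM in this assay, at which 2 of the 4 values shown sit.

On these data alone, it remains open whether both methyl groups are needed or a single methyl group would do. As far as these compounds go, how a methoxy group or an amine on that outer ring would read also remains open.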